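Below the limit: from trifluoromethyl to chloro

The source may report more compounds than this note shows. Statements on the series, on what has been measured and on what is new or still open speak of the compounds shown alone.

Results in an ADME assay for permeability, using PAMPA; a lower number here means that the compound crosses the layer more slowly, a higher number that the compound crosses the layer faster:
Compound 1 `O=C(Nc1ccc([N+](=O)[O-])cc1)c1cc(Cl)ccc1O`: 127 10^-6 cm/s
Compound 2 `O=C(Nc1ccc(C(F)(F)F)cc1)c1cc(Cl)ccc1O`: < 22.3 10^-6 cm/s (a limit of the assay)
Compound 3 `O=C(Nc1ccc(C(F)(F)F)cc1Cl)c1cc(Cl)ccc1O`: "not determined" (no result reported)

Compound 2 has no single number in this assay and stands only at a limit of the assay, < 22.3 10^-6 cm/s. For compound 2 the data show (the limit of < 22.3 10^-6 cm/s in this assay, at which 1 of the 3 values shown sits).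

Compound 4 `O=C(Nc1ccc(Cl)cc1)c1cc(Cl)ccc1O` is still to be measured. The change from compound 2 is chloro in place of trifluoromethyl on an aromatic carbon, with chloro in place of trifluoromethyl on an aromatic carbon.

Among the measured compounds shown here, one measured step bears on this change: an at least 5.6-fold lower number from compound 1 to compound 2 (0.75 log units; beyond the scatter), beyond the scatter, with trifluoromethyl in place of nitro on an aromatic carbon. That step does not involve chloro, and compound 2 offers only a limit as a starting point. No step beyond the scatter is therefore expected, and another limit is a real possibility.

The expected change is a step that the limit leaves unreadable from compound 2 to compound 4.

For compound 4 the estimate is 18 10^-6 cm/s, with an expected range from 4 10^-6 cm/s to 70 10^-6 cm/s.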

Compound 4, apparent permeability: 297 10^-6 cm/s
Compound 4: the middle estimate sits 17-fold (1.22 log units) below what was measured; measured number above the stated range.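

In this assay, chloro in place of trifluoromethyl on this aromatic carbon, para to a large group, brings an at least 13-fold higher number from compound 2 to compound 4 (1.12 log units; beyond the scatter), so a low reading is not common to every group at this place. Chloro also separates from nitro at the same carbon, with a 2.3-fold higher number from compound 1 to compound 4 (0.37 log units; beyond the scatter), and this gives the series its first comparison in which the number rises from compound 1. Compound 2 still has a limit of the assay rather than a number, so the first of these steps has only a lower bound: the limit of < 22.3 10^-6 cm/s in this assay, at which 1 of the 4 values shown sits.

Steps involving compound 3 cannot be read, so the effect of the further chloro on the core of compound 2 remains unknown. Going by these compounds, it also remains open whether an amine, a carboxylic acid or a methoxy group at this place would stay near compound 4 or fall towards compound 2.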